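The source may hold more compounds than are shown below. What is called first, only, known or untested is meant among the compounds shown, and "the series" means these compounds.

Compound 1 `Nc1ncnc2c1c(-c1cnc3[nH]ccc3c1)nn2CCCCCCC(=O)NO` gives 50000 nM in a functional assay on A549 cells (Homo sapiens) for inhibition, read by MTT assay, with a stated time of 72 h; a lower number here means a stronger inhibitor, a higher number a weaker inhibitor. Compound 2 `Nc1ncnc2c1c(-c1cnc3[nH]ccc3c1)nn2CCCCC(=O)NO` reaches only a limit of this assay, > 150000 nM, so no exact number is known for it. Trimming the chain produced an at least 3.0-fold higher number from compound 1 to compound 2 (0.47 log units; beyond the scatter), a step resting on (the limit of > 150000 nM in this assay, at which 1 of the 2 values shown sits). Compound 3 `Nc1ncnc2c1c(-c1cnc3[nH]ccc3c1)nn2CCC(=O)NO` trims the chain once more: hydroxycarbamoyl in place of 2-(hydroxycarbamoyl)ethyl on a saturated chain carbon, two bonds along the chain from an aromatic nitrogen. Among the measured compounds shown here, the one measured step of this kind moved toward weaker inhibition, so the same change is expected to leave compound 3 at or beyond the limit, a step that the limit leaves unreadable from compound 2 to compound 3. Compound 3 is therefore estimated at 200000 nM, within 80000 nM to 500000 nM.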

Compound 3, half-maximal inhibitory concentration: > 150000 nM
Compound 3 gave a limit, no number (the forecaster's own chance of this, stated with the estimate: 80%); the middle value is on the limit's open side.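

In this assay compound 3 gives > 150000 nM, which is a limit and not a number. Going by these compounds, the step from compound 2 to compound 3 cannot be read, so the effect of this last trim stays unknown. Compared with compound 1, the shortened chain gives an at least 3.0-fold higher number from compound 1 to compound 3 (0.47 log units; beyond the scatter), which places compound 3 with compound 2 as the weaker inhibitors, a reading that rests on the assay's limit: the limit of > 150000 nM in this assay, at which 2 of the 3 values shown sit.

On these data alone, how far compound 2 and compound 3 really lie from compound 1 remains open. Also open, as far as these compounds go, is whether a longer chain than in compound 1 would lower the number, or whether a carboxylic acid in place of the hydroxycarbamoyl end would change it.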